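Chain Length and Monoamine Oxidase A Inhibition in Propargylamines

A few compounds are considered here, and "the series" means these few. Any claim that something is new, unique, unknown or untested is made for them only; others in the source may bear on it.

Measured compounds:
compound 1, `C#CCN(C)CCCCCOc1ccc2c(c1)CCC2=O`, 31%
compound 2, `C#CCN(C)CCCOc1ccc2c(c1)OCCC2=O`, 32.1%
compound 3, `C#CCN(C)CCCCOc1ccc(C(C)=O)cc1`, 28.6%

In an ADME assay on BTI cells for inhibition of Amine oxidase [flavin-containing] A (Homo sapiens), read by fluorescence and Amplex Red, with a stated time of 15 min, tested at 100 uM (on this read-out higher numbers stand for more inhibition at the one concentration tested (going by the name of the read-out) and lower numbers for less inhibition), compound 1 gives 31%, compound 2 gives 32.1% and compound 3 gives 28.6%. Compound 3 stands with the lowest of the three numbers, yet the nearest number, that of compound 1, and the furthest, that of compound 2, both lie within the scatter of it, so the three compounds cannot be told apart on these data.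

Compound 4, `C#CCN(C)CCCCCCOc1ccc(C(C)=O)cc1`, has not yet been measured. It differs from compound 3 in one place: 2-(methyl(propargyl)amino)ethyl in place of methyl(propargyl)amino on a saturated chain carbon, four bonds along the chain from an oxygen on an aromatic ring. Going by the values given here, no pair of measured compounds shows the effect of such a change, so there is no step to lean on.

Compound 3 is the point of reference. The three measured numbers sit close together while the chain between the amine and the aromatic oxygen varies, so the step from compound 3 to compound 4 is expected to be none beyond the scatter, a number 2.4 percentage points higher from compound 3 to compound 4 (within the scatter). Compound 4 is therefore estimated to give 31%, with a range from 17% to 46%.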

Compound 4, a percentage reported as inhibition, at one concentration (the size of the read-out at that concentration, not a potency): 37.3%
Estimate against measurement, compound 4: 6.3 percentage points below; the measured number falls inside the stated range.
By their numbers in this assay, from the lowest: compounds 3, 1, 2 and 4 (each within the scatter of the next).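

Going by these compounds alone, the result gives the first step at this position: in this assay, 2-(methyl(propargyl)amino)ethyl in place of methyl(propargyl)amino on a saturated chain carbon, four bonds along the chain from an oxygen on an aromatic ring, gives a number 8.7 percentage points higher from compound 3 to compound 4 (within the scatter). This single pair therefore shows that going from 5 heavy atoms to 7 in this group, with the amine and its triple bond kept, leaves the inhibition reading indistinguishable at the one concentration tested. Nothing available explains or bears on this result.

Going by these compounds, whether a still longer chain, or a dimethylamino group in place of the propargyl-bearing amine, would carry the number beyond the scatter remains open. So does whether the same chain change would give a comparable step on the cores of compound 1 and compound 2.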